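Swapping the urea aryl group: dichlorophenyl to trifluoromethylphenyl

This account rests on a few compounds, and the source may have more. Where it says the series, first, only, none or still open, it means among the compounds named here.

Of the compounds shown here, three sharing one core have been tested in a functional assay on MDA-MB-231 cells (Homo sapiens) for inhibition, read by sulforhodamine B assay, with a stated time of 48 h; a higher number here means a weaker inhibitor of growth, a lower number a stronger inhibitor of growth. Compound 1 `O=C(Nc1cccc(-n2cc(-c3ccncc3)c(-c3ccc(Cl)c(O)c3)n2)c1)Nc1cccc(C(F)(F)F)c1` gives 3590 nM, compound 2 `COc1cc(-c2nn(-c3cccc(NC(=O)Nc4cc(C(F)(F)F)cc(C(F)(F)F)c4)c3)cc2-c2ccncc2)ccc1Cl` gives 664 nM, and compound 3 `COc1cc(-c2nn(-c3cccc(NC(=O)Nc4ccc(Cl)c(Cl)c4)c3)cc2-c2ccncc2)ccc1Cl` gives 698 nM. On these numbers compound 3 stands second highest of the three; its value and that of compound 2 lie within the usual scatter of each other, so no order between them can be claimed, while compound 1 sits well beyond the scatter at the weaker end.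

The next compound, compound 4 `COc1cc(-c2nn(-c3cccc(NC(=O)Nc4cccc(C(F)(F)F)c4)c3)cc2-c2ccncc2)ccc1Cl`, keeps everything in compound 3 except the aryl group on the urea: 3-(trifluoromethyl)phenyl in place of 3,4-dichlorophenyl on an amide-type nitrogen. Going by the values given here, no pair of measured compounds shows exactly this exchange, so the size of the step is open. Compound 1 does carry the same 3-(trifluoromethyl)phenyl group but differs elsewhere as well, so the value of compound 1 3590 nM is an uncertain guide. The estimated step of a 1.6-fold higher number from compound 3 to compound 4 (0.20 log units; within the scatter) is therefore small and toward a weaker inhibitor, possibly not beyond the scatter. Compound 4 is expected to give about 1100 nM in this assay, within a range from 450 nM to 2800 nM.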

Compound 4, concentration for 50% growth inhibition: 811 nM
Compound 4: the middle estimate sits 1.4-fold (0.13 log units) above what was measured; the range from low to high includes it.
By their numbers in this assay, from the lowest: compounds 2, 3 and 4 (each within the scatter of the next); then compound 1.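

In this assay, placing 3-(trifluoromethyl)phenyl on the amide-type nitrogen in place of 3,4-dichlorophenyl gives a 1.2-fold higher number from compound 3 to compound 4 (0.07 log units; within the scatter), and hydrogen in place of one trifluoromethyl on the aromatic carbon gives a 1.2-fold higher number from compound 2 to compound 4 (0.09 log units; within the scatter), so no difference can be read among the three urea aryl groups of compound 2, compound 3 and compound 4. Going by these compounds alone, the one clear step lies elsewhere: with the 3-(trifluoromethyl)phenyl group held constant, methyl in place of hydrogen on the oxygen on the aromatic ring gives a 4.4-fold lower number from compound 1 to compound 4 (0.65 log units; beyond the scatter), which separates this change from any change in the urea aryl group. No measurement shown here explains either result.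

On these data alone, it remains open whether a plain phenyl group, or a phenyl group carrying an amine or a carboxylic acid, would stay within the same narrow band at the urea position. As far as these compounds go, it is also open whether a longer chain on that oxygen, such as ethyl, would keep the number of compound 4 or shift it, and whether the step at the oxygen would be the same size with another urea aryl group.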